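Dithiocarbamate–triazole series: aryl to benzyl swap on the ring nitrogen

This account rests on a few compounds, and the source may have more. Where it says the series, first, only, none or still open, it means among the compounds named here.

Of the compounds shown here, two have numbers so far. In a functional assay on MGC-803 cells (Homo sapiens) for inhibition, read by MTT assay, with a stated time of 72 h (a lower number here means a stronger inhibitor, a higher number a weaker inhibitor), compound 1 `COc1ccc(-n2cc(CSC(=S)N3CCN(C(=O)OC(C)(C)C)CC3)nn2)cc1` gives 87300 nM, the highest of the two. Compound 2 `COc1cc(Cn2cc(CSC(=S)N3CCN(C(=O)OCc4ccccc4)CC3)nn2)cc(OC)c1OC` gives 10900 nM in this assay, a lower number than compound 1, and the gap between the two lies beyond the scatter. For the measured compounds named here, compound 2 differs from compound 1 in more than one place, so no single step can be read from that pair; the two values show only that the benzyl-bearing member returns the lower number.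

Compound 3 `CC(C)(C)OC(=O)N1CCN(C(=S)SCc2cn(Cc3ccccc3Cl)nn2)CC1` is not yet measured. It keeps the core of compound 1 with its tert-butyl carbamate and changes only the group on the five-membered ring: 2-chlorobenzyl in place of 4-methoxyphenyl on an aromatic nitrogen. Going by the values given here, no measured step tells what this exchange does on its own. Among the compounds with values here, the only related pointer is compound 2, whose value 10900 nM in this assay sits below that of compound 1 while also carrying a benzyl on that nitrogen; with the carbamate also changed there, that pointer is weak.

For compound 3 the expected step of a 2.9-fold lower number from compound 1 to compound 3 (0.46 log units; beyond the scatter) is a moderate move toward a lower number, beyond the scatter but short of the gap to compound 2. Compound 3 is estimated at 30000 nM in this assay, with a range from 8000 nM to 120000 nM.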

Compound 3, half-maximal inhibitory concentration: 490 nM
Compound 3: middle estimate off by 61-fold (1.79 log units), on the high side; measured number below the stated range.
By their numbers in this assay, from the lowest: compound 3; then compound 2; then compound 1.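

With the tert-butyl carbamate and the rest of the core of compound 1 held fixed, putting 2-chlorobenzyl in place of 4-methoxyphenyl on the aromatic nitrogen of the five-membered ring gives, in this assay, a 180-fold lower number from compound 1 to compound 3 (2.25 log units; beyond the scatter), so this position alone can carry a large change in the read-out, which the pair of compound 1 and compound 2 could not show. The two groups match in heavy-atom count, at 8 each, and each holds one six-membered aromatic ring of carbon only, so the step arises without any change in that count; the leaving group has 1 hydrogen-bond acceptor and the entering group has 0. For the compounds shown here, nothing measured so far accounts for the size of this step.

The single exchange bundles the move from an aryl to a benzyl group with the move from methoxy to chlorine, and the compounds shown do not separate the two. Also open, from the compounds shown here alone, are how a plain unsubstituted benzyl, a longer phenethyl chain or an amine on the ring of that group would read at this nitrogen, and whether the step carries over to the benzyl carbamate of compound 2.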